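The source may hold more compounds than are shown below. What is called first, only, known or untested is meant among the compounds shown, and "the series" means these compounds.

Going by the values given here, in an ADME assay on NIH3T3 cells (Mus musculus) for cytotoxicity (a lower number here means that less compound is needed, a higher number that more compound is needed for the effect), compound 1 `Cc1cc(Oc2cccc(Cn3ccnn3)c2)cc(C)c1Cl` gives 66800 nM, the only actual number available so far. Compound 2 `Cc1cc(Oc2cccc(Cn3ccc4ccccc43)c2)cc(C)c1Cl` reads > 100000 nM, which is a limit of the assay and not a number. Compound 1 is therefore the single numerical reference point for the next compound. Compound 3 `Cc1nnc(-c2cccc(Oc3cc(C)c(Cl)c(C)c3)c2)o1` keeps the core of compound 1 and carries 5-methyl-1,3,4-oxadiazol-2-yl in place of (1H-1,2,3-triazol-1-yl)methyl on an aromatic carbon. Both groups are a five-membered aromatic ring with 3 hetero atoms and carry no net charge. Among the compounds with values here, no measured step bears on this exchange, so the expectation rests only on compound 1 at 66800 nM and on the structural change. The expected step, a 1.1-fold lower number from compound 1 to compound 3 (0.05 log units; within the scatter), is none beyond the usual scatter in this assay. For compound 3 the estimated value is 60000 nM, with an expected range from 25000 nM to 100000 nM.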

Compound 3, half-maximal effective concentration: 46100 nM
Compound 3: middle estimate off by 1.3-fold (0.11 log units), on the high side; the measured number falls inside the stated range.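

Setting 5-methyl-1,3,4-oxadiazol-2-yl in place of (1H-1,2,3-triazol-1-yl)methyl, on an aromatic carbon meta to a large group, gives in this assay a 1.4-fold lower number from compound 1 to compound 3 (0.16 log units; within the scatter). Going by these compounds alone, this is the first readable step at this position, and it shows that one uncharged five-membered aromatic ring with 3 hetero atoms can replace another here without a change beyond the scatter. Compound 2 is a limit and not a number, so no step from it can be read, and the room upward in this assay is bounded: the limit of > 100000 nM in this assay, at which 1 of the 3 values shown sits.

The compounds shown leave open whether a group of another kind at this place, such as an amine or a carboxylic acid, would move the number beyond the scatter. They also leave open whether a change on the shared core itself would do so.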